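This account rests on a few compounds, and the source may have more. Where it says the series, first, only, none or still open, it means among the compounds named here.

The measured compounds are: compound 1, `COc1ccc2c(/C=C/C(=O)c3cc(N)c(OC)c(OC)c3)cn(C)c2c1`, with 106 nM; compound 2, `COc1ccc2c(/C=C/C(=O)c3cc(N)c(OC)c(OC)c3)c[nH]c2c1`, with 193 nM; and compound 3, `COc1cc(C(=O)/C(C)=C/c2cn(C)c3ccccc23)cc([Se]C)c1OC`, with 18 nM, all in a functional assay on A549 cells (Homo sapiens) for antiproliferative activity, read by MTT assay, with a stated time of 48 h; a higher number here means a weaker inhibitor, a lower number a stronger inhibitor.

Compound 2 gives the highest of the three numbers in this assay. Within the data shown here, its nearest neighbour is compound 1, and the only single-site step measured, a 1.8-fold higher number from compound 1 to compound 2 (0.26 log units; within the scatter), lies within the scatter, so these two cannot be ordered. Compound 3, with 18 nM, gives a lower number than compound 2, with 193 nM, a gap beyond the scatter, but the two differ at several places at once, so no single step can be read from that pair.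

Compound 4, `COc1ccc2c(/C=C/C(=O)c3cc(OC)c(OC)c([Se]C)c3)c[nH]c2c1`, is not yet measured. It differs from compound 2 as follows: a group of 2 heavy atoms (1 carbon, 1 selenium; no ring) in place of one nitrogen atom, on an aromatic carbon. Among the measured compounds shown here, no measured step isolates this change. For the measured compounds named here, the one step on record, from compound 1 to compound 2, concerns the aromatic nitrogen and does not bear on it. Going by the values given here, the only hint is that compound 3, the sole compound carrying the entering group, has 18 nM. On that basis a decrease in the number is expected for compound 4, a 3.2-fold lower number from compound 2 to compound 4 (0.51 log units; beyond the scatter), but with wide uncertainty. Compound 4 is therefore estimated at 60 nM, within a range of 20 nM to 180 nM.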

Compound 4, half-maximal inhibitory concentration: 67 nM
The estimate for compound 4 lay 1.1-fold (0.05 log units) below the measured number, and the stated range covers the measured number.
By their numbers in this assay, from the lowest: compound 3; then compounds 4, 1 and 2 (each within the scatter of the next, the first and the last beyond it).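

Among these compounds, compound 4 gives the first reading of this position, on an aromatic carbon ortho to a methoxy group, since the earlier single-site step concerned only the aromatic nitrogen. In this assay, replacing the amino group with the group of one carbon and one selenium atom on an otherwise unchanged core gives (a 2.9-fold lower number from compound 2 to compound 4 (0.46 log units; beyond the scatter)), a modest change beyond the scatter, which shows that the amino group, with its hydrogen-bond donor and acceptor, is not needed at this place for a number in this range, and that the entering group, with neither donor nor acceptor, is accepted there; nothing available explains why the number moves in this direction.

The compounds shown leave open whether the selenium atom itself matters, as a methylthio group or a plain hydrogen at this same place would be needed to tell. They also leave open whether the same exchange would give a step of similar size on the core of compound 1, which carries a methyl group on the aromatic nitrogen.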